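Swapping piperidin-1-yl for (pyridin-2-yl)amino on a carbonyl carbon

The source may report more compounds than this note shows. Statements on the series, on what has been measured and on what is new or still open speak of the compounds shown alone.

Measured so far in a functional assay on KYSE-410 cells (Homo sapiens) for antiproliferative activity, read by MTT assay, with a stated time of 72 h; a lower number here means a stronger inhibitor, a higher number a weaker inhibitor:
- Compound 1 `O=C(c1cc(=O)[nH]c2cc(Br)ccc12)N1CCCCC1` gives > 20000 nM as a limit
- Compound 2 `COc1ccccc1NC(=O)c1cc(=O)[nH]c2cc(Br)ccc12` gives > 20000 nM as a limit
- Compound 3 `COc1ccc(NC(=O)c2cc(=O)[nH]c3cc(Br)ccc23)cc1` gives > 20000 nM as a limit

Compound 1 has no exact number, only a limit, and the same is true of compound 2 and compound 3 (the limit of > 20000 nM in this assay, at which 3 of the 3 values shown sit). Among the measured compounds shown here, no two measured compounds differ in just one place, so the data offer no measured step to compare with.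

The next compound, compound 4 `O=C(Nc1ccccn1)c1cc(=O)[nH]c2cc(Br)ccc12`, keeps the core of compound 1 but carries (pyridin-2-yl)amino in place of piperidin-1-yl on a carbonyl carbon.

With nothing yet measured below the limit in this assay, there is no sign that this swap brings a real gain, so no change beyond the usual scatter is expected. The expected step is a number no higher from compound 1 to compound 4 (the limit leaves the size open) and it remains an estimate. Compound 4 is estimated at 20000 nM (expected range 8000 nM to 50000 nM).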

Compound 4, half-maximal inhibitory concentration: 9800 nM
Compound 4: the middle estimate sits 2.0-fold (0.31 log units) above what was measured, within the range that was stated.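

In this assay, among the compounds shown here, the carbonyl carbon turns out to be a place where a change can bring a compound to an exact number: compound 4 is the first here that is not a limit. Putting (pyridin-2-yl)amino in place of piperidin-1-yl, which also replaces a non-aromatic ring with an aromatic one and adds a hydrogen-bond donor and acceptor, gives an at least 2.0-fold lower number from compound 1 to compound 4 (0.30 log units; that floor lies within the scatter). The true size of this step stays unknown, and a real gain is not yet secure, because the starting point is only a limit, as for most of this set: the limit of > 20000 nM in this assay, at which 3 of the 4 values shown sit.

From the compounds shown here alone, it remains open whether a plain phenylamino group or a (pyridin-3-yl)amino group would also give an exact number. Going by these compounds, the effect of an amine or a carboxylic acid on the pyridine ring of compound 4 is equally open.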